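The compounds below may be only part of what the source reports. "The series", "measured", "known", "first", "only" and "open" are said of these compounds alone.

Measured compounds:
Compound 1, `COc1cc(-c2nn(-c3cccc(NC(=O)c4cccc(C(F)(F)F)c4)c3)cc2-c2ccncc2)ccc1Cl`; in a functional assay on U-251 cells (Homo sapiens) for inhibition, read by sulforhodamine B assay, with a stated time of 48 h (a higher number here means that more compound is tolerated, a lower number that less compound is tolerated), compound 1 gives > 50000 nM, which is a limit of the assay and not a number.
Compound 2, `COc1cc(-c2nn(-c3cccc(NC(=O)Nc4cccc(C(F)(F)F)c4)c3)cc2-c2ccncc2)ccc1Cl`; in this assay compound 2 gives 2920 nM.

Compound 2 carries the only number shown in this assay; the other value shown is a limit, as noted under (the limit of > 50000 nM in this assay, at which 1 of the 2 values shown sits). Going by the values given here, the one measured step, an at least 17-fold lower number from compound 1 to compound 2 (1.23 log units; beyond the scatter), is large and beyond the scatter.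

Compound 3, `COc1cc(-c2nn(-c3cccc(NC(=O)c4ccc(Cl)c(C(F)(F)F)c4)c3)cc2-c2ccncc2)ccc1Cl`, differs from compound 2 by 4-chloro-3-(trifluoromethyl)phenyl in place of (3-(trifluoromethyl)phenyl)amino on a carbonyl carbon. This change removes the urea-type linkage that compound 2 holds and restores an amide with an aryl group on the carbonyl carbon, as in compound 1, now with a chloro substituent added. The measured step from compound 1 to compound 2 bears directly on this: it was large, and compound 3 moves back in the opposite direction. Among the compounds with values here, the added chloro has no measured counterpart, so its effect is open. The expectation for compound 3 in this assay is therefore a markedly higher number than for compound 2, a step of a 10-fold higher number from compound 2 to compound 3 (1.01 log units; beyond the scatter), with a fair chance that only a limit is reported. Compound 3 is estimated at 30000 nM, within 8000 nM to 100000 nM.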

Compound 3, concentration lethal to 50% of the cells: > 32500 nM
Compound 3 gave a limit, no number; the forecaster's own chance of this, stated with the estimate: 45%; at least 1.0-fold (0.03 log units) between middle value and limit.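

In this assay, 4-chloro-3-(trifluoromethyl)phenyl in place of (3-(trifluoromethyl)phenyl)amino on a carbonyl carbon gives an at least 11-fold higher number from compound 2 to compound 3 (1.04 log units; beyond the scatter), so this replacement is large and beyond the scatter, also with the chloro present. Compound 3 stands at a limit of the assay and not at a number: the limit of > 32500 nM in this assay, at which 1 of the 3 values shown sits.

Across the three compounds, the two with an aryl group directly on the carbonyl carbon, compound 1 and compound 3, both give limits, and only compound 2, with the aryl amino group at this place, gives a number, a pattern that rests on a single compound with that group.

As far as these compounds go, the step from compound 1 to compound 3 cannot be read, both values being limits, so the effect of the chloro in this assay remains open. Also open, from the compounds shown here alone, is what a methylamino or an oxygen link on that carbonyl carbon would give, set against compound 2 with 2920 nM.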